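Cytotoxicity limits and a new chlorinated biaryl

The source may hold more compounds than are shown below. What is called first, only, known or untested is meant among the compounds shown, and "the series" means these compounds.

Measured so far in a functional assay on HepG2 cells (Homo sapiens) for cytotoxicity, with a stated time of 72 h; a higher number here means that more compound is needed for the effect, a lower number that less compound is needed (all three values are limits):

- Compound 1 `C=C[C@@](C)(/C=C/c1ccc(Nc2ccccc2)cc1)CCC=C(C)C` gives > 52000 nM as a limit
- Compound 2 `C=C[C@@](C)(/C=C/c1ccc(Nc2cc(F)cc(F)c2)cc1)CCC=C(C)C` gives > 52000 nM as a limit
- Compound 3 `C=C[C@@](C)(/C=C/c1ccc(-c2cccc(F)c2)cc1)CCC=C(C)C` gives > 52000 nM as a limit

Compound 3 reports > 52000 nM and this is a limit, not a number. Within the data shown here, the whole set shows the same thing, with the limit of > 52000 nM in this assay, at which 3 of the 3 values shown sit, and no readable value so far.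

Compound 4 `C=C[C@@](C)(/C=C/c1ccc(-c2ccc(Cl)cc2)cc1)CCC=C(C)C` has 4-chlorophenyl in place of 3-fluorophenyl on an aromatic carbon, para to a large group (4-chlorophenyl in place of 3-fluorophenyl on an aromatic carbon). Among the measured compounds shown here, two measured steps bear on this change, namely a step that the two limits leave unreadable from compound 1 to compound 3 and a step that the two limits leave unreadable from compound 2 to compound 3 and neither gives a size. Neither step points in a direction, so no clear move is expected in this assay and another limit is the likeliest report. The expected step is a step that the limit leaves unreadable from compound 3 to compound 4 and this is only an estimate. For compound 4 the estimated value is 60000 nM with an expected range from 25000 nM to 120000 nM in case a number is reported at all.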

Compound 4, half-maximal effective concentration: > 52000 nM
Compound 4: only a limit was reported; the forecaster's own chance of this, stated with the estimate: 75%; the middle value does not contradict the limit.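

In this assay compound 4 gives > 52000 nM, which is a limit and not a number. No step among compound 1, compound 2, compound 3 and compound 4 can be read, because all of them end at the same limit: the limit of > 52000 nM in this assay, at which 4 of the 4 values shown sit.

The compounds shown leave open how far they truly differ in this assay, and what concentration, if any, would give a readable value.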